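A Methylpiperazine Swap at the Assay Limit

The compounds below may be only part of what the source reports. "The series", "measured", "known", "first", "only" and "open" are said of these compounds alone.

Compound 1 (`O=C(CN1CCCC1)Nc1ccc2ncnc(Nc3cccc(C(F)(F)F)c3)c2c1`) and compound 2 (`O=C(CN1CCCC1)Nc1ccc2ncnc(Nc3cccc(Cl)c3)c2c1`) share one core and differ only on an aromatic carbon. In a functional assay on MCF7 cells (Homo sapiens) for antiproliferative activity, read by MTT assay, with a stated time of 48 h (on this read-out lower numbers stand for stronger inhibition and higher numbers for weaker inhibition), compound 1 gives > 100000 nM as its result, which is a limit and not a number. Compound 2 gives > 100000 nM as its result, which is also a limit. Compound 2 therefore stands at the limit of > 100000 nM in this assay, at which 2 of the 2 values shown sit, and has no number of its own.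

Among the measured compounds shown here, the only measured step is a step that the two limits leave unreadable from compound 1 to compound 2 with chloro in place of trifluoromethyl on an aromatic carbon, and it offers no size to carry forward. Compound 3 (`CN1CCN(CC(=O)Nc2ccc3ncnc(Nc4cccc(Cl)c4)c3c2)CC1`) has 4-methylpiperazin-1-yl in place of pyrrolidin-1-yl on a saturated chain carbon bound to a carbonyl carbon, counted as 4-methylpiperazin-1-yl in place of pyrrolidin-1-yl on a saturated chain carbon bound to a carbonyl carbon in full. For the measured compounds named here, no measured step covers this change, so no step beyond the scatter is expected in this assay for it. That expectation starts from compound 2 at > 100000 nM as a limit. The expected change is a number no higher from compound 2 to compound 3 (the limit leaves the size open) in size. For compound 3 the estimate is 100000 nM with an expected range from 30000 nM to 300000 nM and a good chance of another limit.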

Compound 3, half-maximal inhibitory concentration: > 100000 nM
Compound 3 gave a limit, no number (the forecaster's own chance of this, stated with the estimate: 70%); the middle value lies on the limit itself.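

No step can be read from compound 2 to compound 3 in this assay for the swap to 4-methylpiperazin-1-yl, because both results are limits and not numbers, and all the compounds shown share one limit: the limit of > 100000 nM in this assay, at which 3 of the 3 values shown sit.

The compounds shown leave open what number belongs to each of them, and whether either change alters the result at all.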